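Notes on the acyl group across compounds 1 to 3

The compounds below may be only part of what the source reports. "The series", "measured", "known", "first", "only" and "open" are said of these compounds alone.

Measured so far:
compound 1, `CC(=O)N1N=C(c2ccc(-n3ccnc3)cc2)CC1c1ccc(N(C)C)cc1`, -9.7%
compound 2, `CN(C)c1ccc(C2CC(c3ccc(-n4ccnc4)cc3)=NN2C(=O)c2ccc(F)cc2)cc1`, 7.1%

In a functional assay on HCC1806 cells (Homo sapiens) for inhibition, read by sulforhodamine B assay, tested at 10 uM (a lower number here means less inhibition, a higher number more inhibition at the concentration tested (going by the name of the read-out)), compound 2 gives 7.1%, the higher of the two numbers; compound 1 gives -9.7%. For the measured compounds named here, the one measured step, a number 16.8 percentage points higher from compound 1 to compound 2 (beyond the scatter), replaces methyl on the carbonyl carbon with 4-fluorophenyl and moves the read-out beyond the scatter, though only modestly.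

Compound 3, `CN(C)c1ccc(C2CC(c3ccc(-n4ccnc4)cc3)=NN2C(=O)c2ccc(C(F)(F)F)cc2)cc1`, differs from compound 2 in this way: trifluoromethyl in place of fluoro on an aromatic carbon. Going by the values given here, no measured step changes a substituent on that aromatic ring, so the only guide is that the acyl group matters at all, as a number 16.8 percentage points higher from compound 1 to compound 2 (beyond the scatter) shows. A further change within the same ring is therefore expected to give a step of uncertain sign, most likely within the scatter: a number 4.9 percentage points higher from compound 2 to compound 3 (within the scatter). Compound 3 is estimated at 12%, with a range from -8% to 32%.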

Compound 3, a percentage reported as inhibition, at one concentration (the size of the read-out at that concentration, not a potency): 28%
Compound 3: the middle estimate sits 16 percentage points below what was measured; low and high end bracket the measured number.
By their numbers in this assay, from the lowest: compound 1; then compound 2; then compound 3.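

In this assay, the substituent on the aromatic carbon para to a large group matters in its own right: trifluoromethyl in place of fluoro gives a number 20.9 percentage points higher from compound 2 to compound 3 (beyond the scatter), so the acyl effect is not confined to the swap from methyl to an aryl group. Measured against the methyl on the carbonyl carbon, 4-(trifluoromethyl)phenyl gives a number 37.7 percentage points higher from compound 1 to compound 3 (beyond the scatter), a large step where 4-fluorophenyl gave only a modest one. Nothing at hand explains the rise in the read-out.

As far as these compounds go, two fluorinated substituents at one position do not define a trend, so it remains open how a nitrile, a methoxy or a carboxylic acid on that carbon would read. From the compounds shown here alone, with a single tested concentration, the potency of compound 3 also remains open.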